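This account rests on a few compounds, and the source may have more. Where it says the series, first, only, none or still open, it means among the compounds named here.

The measured compounds:
compound 1, `C=CCOc1ccc(C(=O)Nc2cccc(C)n2)cc1`, 31700 nM;
compound 2, `C#CCOc1ccc(C(=O)Nc2cccc(C)n2)cc1`, 21700 nM;
compound 3, `CCCCCNc1cccc(NC(=O)c2ccc(OCCC)cc2)n1`, > 100000 nM.

All three share the same core and were tested in an in vitro assay on HEK-tsA201 cells for antagonist activity at Neuronal acetylcholine receptor; alpha3/beta4 (Homo sapiens), read by fluorescence and calcium flux; on this read-out higher numbers stand for weaker inhibition and lower numbers for stronger inhibition. Among the compounds with values here, compound 1 and compound 2 differ only in the group on the oxygen, and the step of a 1.5-fold lower number from compound 1 to compound 2 (0.16 log units; within the scatter) is the sole step between two measured numbers. For compound 3 the value > 100000 nM is a limit of the assay, not a number. This is the limit of > 100000 nM in this assay, at which 1 of the 3 values shown sits, so compound 3 stands at the weak end of what this assay can report, with no number to set against the other two.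

Compound 4, `CCCOc1ccc(C(=O)Nc2cccc(Nc3ccc(Cl)cc3)n2)cc1`, is not yet measured. It differs from compound 3 in one place: 4-chlorophenyl in place of pentyl on a nitrogen on an aromatic ring. Within the data shown here, no measured step touches the nitrogen on the aromatic ring; the only measured step, a 1.5-fold lower number from compound 1 to compound 2 (0.16 log units; within the scatter), lies elsewhere and within the scatter, so it gives no guide to the size or direction of this change. Starting from a limit, any number reported for compound 4 would in itself mean stronger inhibition. The step of an at least 1.6-fold lower number from compound 3 to compound 4 (0.22 log units; that floor lies within the scatter) is expected, with a real chance that this assay again reports only a limit. Compound 4 is estimated at 60000 nM, within a range from 15000 nM to 100000 nM.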

Compound 4, half-maximal inhibitory concentration: > 100000 nM
Compound 4 ended at the assay's limit; the forecaster's own chance of this, stated with the estimate: 50%; middle value at least 1.6-fold (0.22 log units) away from the limit.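

Within the data shown here, compound 3 and compound 4 both give only a limit, not a number, so no step between them can be read and the change from pentyl to 4-chlorophenyl shows neither size nor direction: the limit of > 100000 nM in this assay, at which 2 of the 4 values shown sit. The compounds shown leave open whether any group on that nitrogen gives a readable number, and how compound 3 and compound 4 truly compare.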